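Cytotoxicity on the shared core, towards compound 4

The source may report more compounds than this note shows. Statements on the series, on what has been measured and on what is new or still open speak of the compounds shown alone.

Measured so far in an ADME assay on HEK293-A cells (Homo sapiens) for cytotoxicity, read by MTT assay, with a stated time of 48 h; a higher number here means a weaker inhibitor, a lower number a stronger inhibitor:
compound 1 `CN(CCC#N)C[C@H]1CN(c2ccc(-n3cc(-c4ccccn4)cn3)c(F)c2)C(=O)O1` gives > 400 ug/mL, which is a limit of the assay and not a number.
compound 2 `CC(=O)OC[C@H]1CN(c2ccc(-n3cc(-c4ccccn4)cn3)c(F)c2)C(=O)O1` gives > 400 ug/mL, also a limit.
compound 3 `COC[C@H]1CN(c2ccc(-n3cc(-c4ccccn4)cn3)c(F)c2)C(=O)O1` gives > 400 ug/mL, again a limit.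

Compound 3 thus stands at the limit of this assay, where every value seen so far sits (the limit of > 400 ug/mL in this assay, at which 3 of the 3 values shown sit). The three measured steps, a step that the two limits leave unreadable from compound 1 to compound 2, a step that the two limits leave unreadable from compound 1 to compound 3 and a step that the two limits leave unreadable from compound 2 to compound 3, each run between two limits and cannot be read in size or direction; they only show that no change so far on the saturated chain carbon bound to a saturated ring carbon, nor on its oxygen, moved a compound off the limit.

Compound 4 `O=C1O[C@@H](CSc2cccs2)CN1c1ccc(-n2cc(-c3ccccn3)cn2)c(F)c1` differs from compound 3 by (thiophen-2-yl)sulfanyl in place of methoxy on a saturated chain carbon bound to a saturated ring carbon, that is methoxymethyl becoming ((thiophen-2-yl)sulfanyl)methyl. Within the data shown here, no measured step contains the entering (thiophen-2-yl)sulfanyl group, so the evidence bearing on it is only that the two earlier replacements at this place, acetoxy and (2-cyanoethyl)(methyl)amino against methoxy, all left compounds at the limit. Compound 4 is therefore expected to remain at the limit as well, estimated at 400 ug/mL with a range from 150 ug/mL to 800 ug/mL. The expected step is a number no higher from compound 3 to compound 4 (the limit leaves the size open), that is none beyond the scatter.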

Compound 4, half-maximal inhibitory concentration: > 400 ug/mL
Compound 4: no number, only a limit; the forecaster's own chance of this, stated with the estimate: 70%; the middle value lies on the limit itself.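

In this assay compound 4 gives > 400 ug/mL, a limit and not a number. Its steps from compound 1, compound 2 and compound 3 therefore cannot be read in size or direction. The compounds shown leave open whether the groups on the saturated chain carbon bound to a saturated ring carbon differ at all in cytotoxicity: the limit of > 400 ug/mL in this assay, at which 4 of the 4 values shown sit.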